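The compounds below may be only part of what the source reports. "The series", "measured", "known", "first", "only" and "open" are said of these compounds alone.

In a functional assay on MDA-MB-436 cells (Homo sapiens) for antiproliferative activity, read by MTT assay, with a stated time of 48 h (on this read-out higher numbers stand for weaker inhibition and lower numbers for stronger inhibition), three compounds share one core and differ only in the aromatic ring attached to it. Compound 1 `C=CS(=O)(=O)N1CCN(c2ncnc3sc(-c4ccccc4)cc23)CC1` with phenyl gives 21100 nM as its reading. Compound 2 `C=CS(=O)(=O)N1CCN(c2ncnc3sc(-c4ccc(C#N)cc4)cc23)CC1` with 4-cyanophenyl gives 9170 nM and compound 3 `C=CS(=O)(=O)N1CCN(c2ncnc3sc(-c4ccc(OC)nc4)cc23)CC1` with 6-methoxypyridin-3-yl gives 11900 nM as readings. The steps of a 1.8-fold lower number from compound 1 to compound 3 (0.25 log units; within the scatter) and a 1.3-fold higher number from compound 2 to compound 3 (0.11 log units; within the scatter) both stay within the scatter, so this last number has no clear rank against the other two.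

Compound 4 `C=CS(=O)(=O)N1CCN(c2ncnc3sc(-c4ccc(F)nc4)cc23)CC1` differs from compound 3 at one place: fluoro in place of methoxy on an aromatic carbon in short, fluoro in place of methoxy on an aromatic carbon. Going by the values given here, no measured step swaps this group itself. The closest guides are the changes to the outer ring, and only a 2.3-fold lower number from compound 1 to compound 2 (0.36 log units; beyond the scatter) passes the scatter, and then only modestly. No step beyond the scatter is therefore expected in this assay in either direction. The expected step is a 1.0-fold higher number from compound 3 to compound 4 (0.00 log units; within the scatter) for this swap. The estimate for compound 4 is 12000 nM with an expected range from 6000 nM to 24000 nM.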

Compound 4, half-maximal inhibitory concentration: 17500 nM
Beside the measured number, compound 4's estimate is 1.5-fold (0.16 log units) below it, and the stated range covers the measured number.
By their numbers in this assay, from the lowest: compounds 2, 3, 4 and 1 (each within the scatter of the next, the first and the last beyond it).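

In this assay, going by these compounds alone, the swap of methoxy for fluoro on the aromatic carbon next to the ring nitrogen is the first change made at this exact place, and it gives a 1.5-fold higher number from compound 3 to compound 4 (0.17 log units; within the scatter), so replacing methoxy with the single fluorine atom produces no clear shift in the reading. The new 6-fluoropyridin-3-yl compound also has no clear rank against the other outer rings, with a 1.9-fold higher number from compound 2 to compound 4 (0.28 log units; within the scatter) and a 1.2-fold lower number from compound 1 to compound 4 (0.08 log units; within the scatter). No supporting evidence bears on these readings.

From the compounds shown here alone, only methoxy and fluoro have been compared at this place, so it remains open whether an amine or a carboxylic acid there would give a step beyond the scatter. It is also unknown whether the same swap would behave alike on a different outer ring.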